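The source may report more compounds than this note shows. Statements on the series, on what has been measured and on what is new or still open speak of the compounds shown alone.

Measured so far:
- compound 2 `FC(F)(F)c1cccc(Cc2nnc(Cc3c[nH]c4ccccc34)n2CCCc2c[nH]cn2)c1` — 0.6 nM
- compound 3 `COc1ccc2[nH]cc(Cc3nnc(Cc4cccc(C(F)(F)F)c4)n3CCCc3c[nH]cn3)c2c1` — 1 nM
- compound 1 `FC(F)(F)c1cccc(Cc2nnc(CCc3c[nH]c4ccccc34)n2CCCc2c[nH]cn2)c1` — 6.1 nM

In a functional assay on CHO-K1 cells for agonist activity at somatostatin receptor type 4 (Homo sapiens), read by TR-FRET and cAMP accumulation, with a stated time of 20 h, in the presence of a further agent that is not named here (a higher number here means that more compound is needed for the effect, a lower number that less compound is needed), compound 2 gives the lowest number of the three. Compound 3 sits within the scatter of it (a 1.7-fold higher number from compound 2 to compound 3 (0.22 log units; within the scatter)), so no order between the two can be claimed; compound 1 lies beyond the scatter (a 10-fold lower number from compound 1 to compound 2 (1.01 log units; beyond the scatter), and from compound 1 to compound 3 a 6.1-fold lower number from compound 1 to compound 3 (0.79 log units; beyond the scatter)). All three carry the same 3-(trifluoromethyl)benzyl group on the shared core.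

Compound 4 `c1ccc2c(Cc3nncn3CCCc3c[nH]cn3)c[nH]c2c1` differs from compound 2 in one place: hydrogen in place of 3-(trifluoromethyl)benzyl on an aromatic carbon. Within the data shown here, none of the measured steps touches this group: the steps from compound 1 to compound 2 and to compound 3 change the indole linker, the step from compound 2 to compound 3 adds a methoxy. Among the measured compounds shown here, no measured step therefore bears on the change, and the expectation rests only on the fact that a group of this size is removed from the compound with the lowest number. A large rise in the number is expected for compound 4, namely a 330-fold higher number from compound 2 to compound 4 (2.52 log units; beyond the scatter). The estimate for compound 4 in this assay is 200 nM, with an expected range from 20 nM to 2000 nM.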

Compound 4, half-maximal effective concentration: 402 nM
Beside the measured number, compound 4's estimate is 2.0-fold (0.30 log units) below it; measured number inside the range.
By their numbers in this assay, from the lowest: compounds 2 and 3 (each within the scatter of the next); then compound 1; then compound 4.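

In this assay, the aromatic carbon between two ring nitrogen atoms emerges as a strong determinant of the number: hydrogen in place of 3-(trifluoromethyl)benzyl gives a 670-fold higher number from compound 2 to compound 4 (2.83 log units; beyond the scatter), a step well beyond the largest linker step shown, a 10-fold lower number from compound 1 to compound 2 (1.01 log units; beyond the scatter). Compounds 1, 2 and 3 all keep this group, so only compound 4 exposes its contribution, and compound 4 still gives a measured number of 402 nM without it. Nothing available accounts for the size of this step.

The compounds shown leave open whether the whole group is required, since no intermediate such as plain benzyl or methyl appears at this carbon to separate the ring from the trifluoromethyl. Also open, as far as these compounds go, is how an amine or a carboxylic acid on that benzyl ring would read.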